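Phenoxy for arylthio on the shared core: toxicity notes

The source may hold more compounds than are shown below. What is called first, only, known or untested is meant among the compounds shown, and "the series" means these compounds.

Compound 1 `COc1ccc(Sc2nc3cc(N)cc(N)c3nc2-c2ccccc2)cc1` is tested in a functional assay on MDA-MB-435 cells (Homo sapiens) for inhibition, read by sulforhodamine B assay, with a stated time of 48 h; on this read-out higher numbers stand for lower toxicity in this test and lower numbers for higher toxicity in this test. For compound 1 the read-out is a limit of the assay, < 100000 nM. Compound 2 `Nc1cc(N)c2nc(-c3ccccc3)c(Sc3ccc(Cl)c(Cl)c3)nc2c1` carries 3,4-dichlorophenyl in place of 4-methoxyphenyl on the sulfur. For compound 2 the read-out in this assay is also a limit, < 100000 nM. The step that the two limits leave unreadable from compound 1 to compound 2 is therefore left unreadable by the two limits. Among the compounds with values here, compound 2 thus stands only at a limit, and the one further value shown is a limit as well; the limit of < 100000 nM in this assay, at which 2 of the 2 values shown sit, is all the series gives. Compound 3 `Nc1cc(N)c2nc(-c3ccccc3)c(Oc3ccc(F)cc3)nc2c1` differs from compound 2 by 4-fluorophenoxy in place of (3,4-dichlorophenyl)sulfanyl on an aromatic carbon. Within the data shown here, no measured step bears readably on this change, the only one being a step that the two limits leave unreadable from compound 1 to compound 2. Compound 3 is accordingly expected to sit near the same limit, with an expected step that the limit leaves unreadable from compound 2 to compound 3 of no readable direction. The estimate for compound 3 in this assay is 30000 nM, within 5000 nM to 100000 nM, a further limit being the likelier report.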

Compound 3, concentration lethal to 50% of the cells: 67600 nM
Beside the measured number, compound 3's estimate is 2.3-fold (0.35 log units) below it, within the range that was stated.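

No step to compound 3 can be read from compound 1 or compound 2, since both stand only at a limit of the assay: the limit of < 100000 nM in this assay, at which 2 of the 3 values shown sit.

Left open is the size and direction of any change in this assay when 4-fluorophenoxy replaces (3,4-dichlorophenyl)sulfanyl or (4-methoxyphenyl)sulfanyl.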